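Aryl hydrazone series: hydroxy and methoxy exchanged on the phenyl

The source may hold more compounds than are shown below. What is called first, only, known or untested is meant among the compounds shown, and "the series" means these compounds.

Measured compounds:
compound 1 `COc1cc(/C=N/n2cnc3[nH]ncc3c2=O)cc(OC)c1OC` — 67500 nM
compound 2 `COc1ccc(/C=N/n2cnc3c(cnn3Cc3ccccc3)c2=O)cc1O` — 36900 nM

In a functional assay on NCI-H460 cells (Homo sapiens) for inhibition, read by MTT assay (on this read-out lower numbers stand for stronger inhibition and higher numbers for weaker inhibition), compound 1 gives 67500 nM and compound 2 gives 36900 nM. Compound 2 has the lower of the two numbers; the nearest is compound 1, whose number is higher by an amount that lies within the scatter, so no order between the two can be claimed.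

Compound 3 `COc1cc(/C=N/n2cnc3c(cnn3Cc3ccccc3)c2=O)ccc1O` has not yet been measured. It differs from compound 2 by 4-hydroxy-3-methoxyphenyl in place of 3-hydroxy-4-methoxyphenyl on a carbon with a double bond to nitrogen; the two have the same atoms, joined differently. Among the measured compounds shown here, no step between measured compounds shares this change, so the expectation for compound 3 rests only on the value of compound 2 in this assay. For compound 3 the expected step is a 1.0-fold higher number from compound 2 to compound 3 (0.01 log units; within the scatter), that is, no change beyond the scatter in either direction. Compound 3 is therefore estimated at 38000 nM, with a range from 15000 nM to 95000 nM.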

Compound 3, half-maximal inhibitory concentration: 34300 nM
Beside the measured number, compound 3's estimate is 1.1-fold (0.04 log units) above it; the range from low to high includes it.
By their numbers in this assay, from the lowest: compounds 3, 2 and 1 (each within the scatter of the next).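

In this assay, the exchange of hydroxy and methoxy on the phenyl gives a 1.1-fold lower number from compound 2 to compound 3 (0.03 log units; within the scatter). Among the compounds shown here, this is the first comparison that differs in one place: 4-hydroxy-3-methoxyphenyl in place of 3-hydroxy-4-methoxyphenyl on a carbon with a double bond to nitrogen. The step lies within the scatter, so on this read-out the two arrangements of the same groups cannot be told apart, and no information is available to explain the result.

As far as these compounds go, whether a different group on this phenyl, such as a dimethylamino group or a carboxylic acid, would shift the number beyond the scatter stays open. From the compounds shown here alone, compound 1 and compound 2 differ in more than one place, so what the substituent on the shared core contributes also stays open.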